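Swapping the pendant aryl group and watching cytotoxicity

The source may report more compounds than this note shows. Statements on the series, on what has been measured and on what is new or still open speak of the compounds shown alone.

Compound 3, `O=c1cc(-c2ccc(-c3ccccc3)cc2)oc2cc(OCCCCCCCCN3CCCC3)ccc12`, was tested in an ADME assay on HepG2 cells (Homo sapiens) for cytotoxicity, read by MTT assay, with a stated time of 48 h, tested at 1 uM (on this read-out lower numbers stand for a weaker effect and higher numbers for a stronger effect at the one concentration tested), and compound 3 gives 13.9%. Two close relatives share the same core: compound 1, `O=c1cc(-c2ccc(Cl)cc2)oc2cc(OCCCCCCCCN3CCCC3)ccc12`, which in this assay gives 6.39%, and compound 2, `O=c1cc(-c2ccccc2)oc2cc(OCCCCCCCCN3CCCC3)ccc12`, which in this assay gives 11.3%. Of these three numbers compound 3 has the highest, yet the steps leading to it, a number 7.5 percentage points higher from compound 1 to compound 3 (within the scatter) and a number 2.6 percentage points higher from compound 2 to compound 3 (within the scatter), are within the scatter, as is a number 4.9 percentage points higher from compound 1 to compound 2 (within the scatter), so the three compounds cannot really be told apart.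

Compound 4, `O=c1cc(-c2ccccc2O)oc2cc(OCCCCCCCCN3CCCC3)ccc12`, is not yet measured. It differs from compound 3 by 2-hydroxyphenyl in place of 4-phenylphenyl on an aromatic carbon. All three measured steps change the group at this same aromatic carbon, and none of them moved the number beyond the scatter. The expectation is therefore a step of a number 3.9 percentage points lower from compound 3 to compound 4 (within the scatter), which means no real change beyond the scatter. For compound 4 the estimated value in this assay is 10%, with a range from 2% to 20%.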

Compound 4, a percentage reported as inhibition, at one concentration (the size of the read-out at that concentration, not a potency): 5.92%
Beside the measured number, compound 4's estimate is 4.1 percentage points above it; low and high end bracket the measured number.
By their numbers in this assay, from the lowest: compounds 4, 1, 2 and 3 (each within the scatter of the next).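

The hydroxy group is the one new kind of substituent on this aryl ring, and in this assay adding it gives a number 5.4 percentage points lower from compound 2 to compound 4 (within the scatter). This shows that a group with a hydrogen-bond donor and acceptor at this position also does not move the read-out beyond the usual variation. Replacing the other two aryl groups gives a number 8 percentage points lower from compound 3 to compound 4 (within the scatter) and a number 0.5 percentage points lower from compound 1 to compound 4 (within the scatter), so the four compounds still cannot be told apart, and nothing here offers an explanation for the small differences between them.

On these data alone, it remains open whether an amine or a carboxylic acid on this aryl ring would produce a real shift in cytotoxicity. The single tested concentration also leaves open whether these compounds would separate at higher doses.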